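The source may hold more compounds than are shown below. What is called first, only, known or untested is meant among the compounds shown, and "the series" means these compounds.

Compounds measured so far:
compound 1, `CCN(CC)CCCNC(=O)C(c1ccccc1)c1ccccc1`, with 4400 nM in an assay on CHO cells for inhibition of sodium channel protein type 2 subunit alpha (Rattus norvegicus); a lower number here means a stronger inhibitor, a higher number a weaker inhibitor;
compound 2, `O=C(NCCCN1CCC(c2ccccc2)CC1)C(c1ccccc1)c1ccccc1`, with 1100 nM;
compound 3, `O=C(NCCCN1CCC(Oc2ccccc2)CC1)C(c1ccccc1)c1ccccc1`, with 1400 nM.

Compound 3 stands second highest of these three numbers. Its nearest neighbour is compound 2, whose number is lower by a margin within the scatter; its furthest is compound 1, whose number is higher by a margin beyond the scatter.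

The next compound, compound 4, `O=C(NCCCN1CCC(n2c(O)nc3ccccc32)CC1)C(c1ccccc1)c1ccccc1`, has not been measured. It differs from compound 3 in one place: 2-hydroxy-1H-benzimidazol-1-yl in place of phenoxy on a saturated ring carbon.

Going by the values given here, one measured step bears on this position. The step of a 1.3-fold higher number from compound 2 to compound 3 (0.10 log units; within the scatter) shows that exchanging phenyl for phenoxy on that saturated ring carbon left the number essentially unchanged. Among the compounds with values here, the present change is larger in size and brings in a donor and more acceptors, and no measured compound tells how such a group behaves here. On that basis a modest step is expected for compound 4, a 1.6-fold lower number from compound 3 to compound 4 (0.19 log units; within the scatter), with wide uncertainty.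

Compound 4 is therefore estimated at 900 nM, within a range from 250 nM to 3500 nM.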

Compound 4, half-maximal inhibitory concentration: 720 nM
Compound 4: middle estimate off by 1.3-fold (0.10 log units), on the high side, within the range that was stated.
By their numbers in this assay, from the lowest: compounds 4, 2 and 3 (each within the scatter of the next); then compound 1.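

The steps of a 1.9-fold lower number from compound 3 to compound 4 (0.29 log units; within the scatter) and a 1.5-fold lower number from compound 2 to compound 4 (0.18 log units; within the scatter) show that in this assay 2-hydroxy-1H-benzimidazol-1-yl on this saturated ring carbon stays within the scatter of both phenoxy and phenyl. The earlier compounds had shown this only for two groups with one six-membered aromatic ring of carbon only and no hydrogen-bond donor, whereas the new group adds a second aromatic ring, nitrogen atoms and a hydrogen-bond donor with no step beyond the scatter. Nothing at hand gives a cause for this result.

On these data alone, whether a group of another kind on this carbon, such as a primary amine or a carboxylic acid, would also stay within the scatter remains open. So does the outcome of a longer chain joining the amide nitrogen to the ring nitrogen.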